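A few compounds are considered here, and "the series" means these few. Any claim that something is new, unique, unknown or untested is made for them only; others in the source may bear on it.

In an ADME assay on microsomes from liver (Mus musculus) for metabolic stability, read by LC-MS, with a stated time of 10 min, tested at 0.5 uM (on this read-out higher numbers stand for a more stable compound and lower numbers for a less stable compound), compound 1 `c1ccc2c(c1)CN[C@@H](CN(CC1CCNCC1)[C@H]1CCCc3cccnc31)C2` gives 13% and compound 2 `CCN1CCN(CCCN(C[C@H]2Cc3ccccc3CN2)[C@H]2CCCc3cccnc32)CC1` gives 19%. Going by the values given here, these are the only two numbers so far, and they lie within the scatter of each other, so compound 2 cannot be separated from compound 1. Compound 3 `c1ccc2c(c1)CN[C@@H](CN(CC[C@H]1CCCNC1)[C@H]1CCCc3cccnc31)C2` differs from compound 2 in one place: piperidin-3-yl in place of (4-ethylpiperazin-1-yl)methyl on a saturated chain carbon, two bonds along the chain from an amine nitrogen. In words, piperidin-3-yl stands in place of (4-ethylpiperazin-1-yl)methyl on a saturated chain carbon, two bonds along the chain from an amine nitrogen. Among the compounds with values here, only one measured step bears on this change. In a number 6 percentage points higher from compound 1 to compound 2 (within the scatter), 2-(4-ethylpiperazin-1-yl)ethyl replaces piperidin-4-yl, so that step also sets a piperidine-bearing side chain against the ethylpiperazine one. The step is small, and no data yet cover the piperidin-3-yl group itself. A change beyond the scatter in this assay is therefore not expected, and any slight shift would be expected to run towards the value of compound 1 at 13%. The estimated step is a number 4 percentage points lower from compound 2 to compound 3 (within the scatter). The expected value for compound 3 is 15%, with an estimated range from 6% to 30%.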

Compound 3, percent of the compound remaining: 56%
Beside the measured number, compound 3's estimate is 41 percentage points below it, and the stated range ends below it.
By their numbers in this assay, from the lowest: compounds 1 and 2 (each within the scatter of the next); then compound 3.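

In this assay, the side chain at this place proves able to move the read-out well beyond the scatter, which the pair of compound 1 and compound 2 did not show. Piperidin-3-yl in place of (4-ethylpiperazin-1-yl)methyl on a saturated chain carbon, two bonds along the chain from an amine nitrogen, gives a number 37 percentage points higher from compound 2 to compound 3 (beyond the scatter) and so separates this side chain from the ethylpiperazine one. Having a piperidine ring is not enough to account for the result, as (piperidin-3-yl)methyl in place of piperidin-4-yl on a saturated chain carbon bound to an amine nitrogen gives a number 43 percentage points higher from compound 1 to compound 3 (beyond the scatter), and nothing at hand gives a reason for either step.

The last step alters both the point at which the ring is attached and the length of the chain, so the compounds shown do not say how much each contributes, or whether the defined stereocentre of the piperidin-3-yl group plays any part. A 2-(piperidin-4-yl)ethyl group, the opposite stereoisomer of the piperidin-3-yl group or an ethyl group on its ring nitrogen would bear directly on these questions.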